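The source may hold more compounds than are shown below. What is called first, only, known or untested is meant among the compounds shown, and "the series" means these compounds.

Compound 1 `Cc1c(C)c2c(c(C)c1OC(=O)CCC(=O)O)CCC(C)(C(=O)NCC1CC(C)(C)N([O])C1(C)C)O2`: > 300000 nM
Compound 2 `Cc1c(C)c2c(c(C)c1O)CCC(C)(C(=O)NC1CC(C)(C)N([O])C1(C)C)O2`: 144000 nM

Among the compounds with values here, in a functional assay on MT4 cells (Homo sapiens) for cytotoxicity, read by MTT assay, with a stated time of 72 h (on this read-out lower numbers stand for stronger inhibition and higher numbers for weaker inhibition), compound 2 gives 144000 nM, the only exact number so far. Compound 1, which also carries a (2-carboxyethyl)carbonyl group, gives > 300000 nM, and this is a limit of the assay, not a number.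

Compound 3 `Cc1c(C)c2c(c(C)c1OC(=O)CCC(=O)O)CCC(C)(C(=O)NC1CC(C)(C)N([O])C1(C)C)O2` is built from compound 2 by one change: (2-carboxyethyl)carbonyl in place of hydrogen on an oxygen on an aromatic ring. The hydroxy group thus becomes ((2-carboxyethyl)carbonyl)oxy. Within the data shown here, no measured pair of compounds shows this change alone, so any forecast is uncertain. Compound 3 is expected to show weaker inhibition than compound 2, though only modestly, and it may reach the limit of this assay. The expected move is a 1.6-fold higher number from compound 2 to compound 3 (0.20 log units; within the scatter). The estimated value for compound 3 is 230000 nM, within an expected range of 110000 nM to 300000 nM.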

Compound 3, half-maximal inhibitory concentration: > 300000 nM
Compound 3 was reported as a limit; the forecaster's own chance of this, stated with the estimate: 45%; middle value at least 1.3-fold (0.11 log units) away from the limit.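

In this assay, placing (2-carboxyethyl)carbonyl on the oxygen on the aromatic ring gives an at least 2.0-fold higher number from compound 2 to compound 3 (0.31 log units; beyond the scatter). This shows that replacing the hydroxy group of compound 2 with ((2-carboxyethyl)carbonyl)oxy weakens inhibition on this read-out by more than the usual scatter, although the true size of the step stays hidden. Compound 3 gives > 300000 nM, which is a limit of the assay and not a number, and it is not alone in this: the limit of > 300000 nM in this assay, at which 2 of the 3 values shown sit.

The step between compound 1 and compound 3 cannot be read, since both values are limits. As far as these compounds go, whether a shorter acetyl group or a simple methyl group on the same oxygen would also weaken inhibition remains open, as does the effect of an amine at the end of the chain.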